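This account rests on a few compounds, and the source may have more. Where it says the series, first, only, none or still open, it means among the compounds named here.

Working notes on the series. Compound 1 `Cn1cnnc1SCC(=O)Nc1ccc(-c2nc(-c3ccccc3)c(-c3ccccc3)n2C)cc1` gives 89.2% in a functional assay on MCF7 cells (Homo sapiens) for cytotoxicity, read by MTT assay, with a stated time of 24 h, tested at 32 ug/mL; a higher number here means a stronger effect of the compound at the concentration tested, a lower number a weaker effect. Compound 2 `Cn1c(-c2ccc(NC(=O)CSC3=NCCS3)cc2)nc(-c2ccccc2)c1-c1ccccc1` gives 52.5% in the same assay, the lowest of the two numbers, set by a number 36.7 percentage points lower from compound 1 to compound 2 (beyond the scatter). Compound 3 `CN(C)/C=C/N1CCN(CC(=O)Nc2ccc(-c3nc(-c4ccccc4)c(-c4ccccc4)n3C)cc2)CC1` is not yet measured; it differs from compound 2 by a group of 11 heavy atoms (8 carbon, 3 nitrogen; one six-membered non-aromatic ring with 2 hetero atoms) in place of a group of 6 heavy atoms (3 carbon, 1 nitrogen, 2 sulfur; one five-membered non-aromatic ring with 2 hetero atoms), on a saturated chain carbon bound to a carbonyl carbon. Among the measured compounds shown here, only the step from compound 1 to compound 2 bears on this change, and it was large, so a step beyond the scatter in either direction is expected, with the sign uncertain. Compound 3 is estimated at 65%, range 35% to 92%, meaning an expected step of a number 12.5 percentage points higher from compound 2 to compound 3 (beyond the scatter).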

Compound 3, a percentage reported as activity, at one concentration (the size of the read-out at that concentration, not a potency): 25.8%
Compound 3: the middle estimate sits 39.2 percentage points above what was measured, and the stated range ends above it.
By their numbers in this assay, from the lowest: compound 3; then compound 2; then compound 1.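

In this assay, the saturated chain carbon bound to a carbonyl carbon also accepts a group without sulfur, the 4-(2-(dimethylamino)ethenyl)piperazin-1-yl group, but the read-out falls further, with a number 26.7 percentage points lower from compound 2 to compound 3 (beyond the scatter) and a number 63.4 percentage points lower from compound 1 to compound 3 (beyond the scatter). Compound 3 therefore lies lowest of the three, and (4-methyl-4H-1,2,4-triazol-3-yl)sulfanyl remains the highest group at this position. Nothing measured here accounts for these steps. As far as these compounds go, it remains open whether the fall follows the piperazine ring or its 2-(dimethylamino)ethenyl substituent, which an unsubstituted piperazin-1-yl group could separate. From the compounds shown here alone, the contribution of the sulfur link is also open, and a morpholin-4-yl group would not settle it alone.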